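Three Aryl Variants, Then a Naphthalene Substituent

The source may report more compounds than this note shows. Statements on the series, on what has been measured and on what is new or still open speak of the compounds shown alone.

Measured in a functional assay on IGROV-1 cells (Homo sapiens) for inhibition, read by sulforhodamine B assay, with a stated time of 48 h, tested at 10 uM; a lower number here means less inhibition, a higher number more inhibition at the concentration tested (going by the name of the read-out):
Compound 1 `CC(=O)c1ccc(-c2cn3ccnc3c(-c3ccc4ncn(C5CCCCC5)c4c3)n2)cc1` gives 19.1%.
Compound 2 `CCc1ccc(-c2cn3ccnc3c(-c3ccc4ncn(Cc5ccccc5)c4c3)n2)cc1` gives 25%.
Compound 3 `Cc1cccc(-c2cn3ccnc3c(-c3ccc4ncn(Cc5ccccc5)c4c3)n2)c1` gives 9.51%.

Compound 3 has the smallest of these three numbers in this assay. Going by the values given here, its gap to compound 1 lies within the usual scatter, so the two cannot be separated; the gap to compound 2 is larger, and the one measured step, a number 15.5 percentage points lower from compound 2 to compound 3 (beyond the scatter), is beyond the scatter.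

Compound 4 `c1ccc(Cn2cnc3ccc(-c4nc(-c5cccc6ccccc56)cn5ccnc45)cc32)cc1` differs from compound 3 in a single place: naphthalen-1-yl in place of 3-methylphenyl on an aromatic carbon. Among the compounds with values here, no measured step pairs a naphthalen-1-yl with any other group, so the only guidance is that exchanging the aryl group at this position moved the number by a modest amount in the step from compound 2 to compound 3. A change of similar size in either direction is therefore plausible, and the direction is uncertain.

Compound 4 is expected to land near 18%, within 5% to 35%, which means an estimated step of a number 8.5 percentage points higher from compound 3 to compound 4 (within the scatter) in this assay.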

Compound 4, a percentage reported as inhibition, at one concentration (the size of the read-out at that concentration, not a potency): 11.3%
Beside the measured number, compound 4's estimate is 6.7 percentage points above it; the measured number falls inside the stated range.
By their numbers in this assay, from the lowest: compounds 3, 4, 1 and 2 (each within the scatter of the next, the first and the last beyond it).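

Going from 3-methylphenyl to naphthalen-1-yl adds a second six-membered aromatic ring of carbon at this position, yet in this assay the swap gives a number 1.8 percentage points higher from compound 3 to compound 4 (within the scatter) and so cannot be told apart from no change. Replacing 4-ethylphenyl with the same naphthalen-1-yl gives a number 13.7 percentage points lower from compound 2 to compound 4 (beyond the scatter) and is a clearer drop, so among these three aryl groups only compound 2 stands apart, and the added ring does not bring it back to that level. No measurement here explains why these aryl groups differ.

From the compounds shown here alone, it remains open whether an amine or a carboxylic acid on the aryl ring would raise the number. Compound 1 differs from the others in two places, so the effect of its cyclohexyl group on the ring nitrogen cannot be separated from that of its acetyl group.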